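This account rests on a few compounds, and the source may have more. Where it says the series, first, only, none or still open, it means among the compounds named here.

Working notes on the series. Of the compounds shown here, two have been measured in a functional assay on HeLa cells (Homo sapiens) for antiproliferative activity, with a stated time of 5 days; a lower number here means a stronger inhibitor, a higher number a weaker inhibitor. Compound 1 `O=C1C=CC2(C=C1)OCC(=O)N2c1nc(-c2ccc3ccccc3c2Br)nn1-c1ccccc1` gives 290 nM. Compound 2 `O=C1C=CC2(C=C1)OCC(=O)N2c1nc(-c2cccc3ccccc23)nn1-c1ccccc1` gives 70 nM, the lowest of the two numbers; its nearest neighbour is compound 1, and the step of a 4.1-fold lower number from compound 1 to compound 2 (0.62 log units; beyond the scatter) comes with naphthalen-1-yl in place of 1-bromonaphthalen-2-yl on an aromatic carbon.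

Compound 3 `Cc1ccccc1-n1nc(-c2cccc3ccccc23)nc1N1C(=O)COC12C=CC(=O)C=C2` is not yet measured. It differs from compound 2 by methyl in place of hydrogen on an aromatic carbon, the phenyl of compound 2 reading as 2-methylphenyl in compound 3. Among the measured compounds shown here, the one measured step concerns the other aryl group and does not touch this ring, so no measured step bears directly on the change. With nothing to go on, no shift beyond the scatter is expected in this assay in either direction. The expected step of no change at the digits printed from compound 2 to compound 3 (within the scatter) is accordingly small. Compound 3 is estimated at 70 nM, in the range 25 nM to 200 nM.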

Compound 3, half-maximal inhibitory concentration: 100 nM
Beside the measured number, compound 3's estimate is 1.4-fold (0.15 log units) below it; the range from low to high includes it.
By their numbers in this assay, from the lowest: compounds 2 and 3 (each within the scatter of the next); then compound 1.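

In this assay, the phenyl ring gives its first reading with a 1.4-fold higher number from compound 2 to compound 3 (0.15 log units; within the scatter), whereas the earlier step concerned only the other aryl group. Methyl on this aromatic carbon, ortho to a large group, therefore brings no change beyond the scatter, and the phenyl to 2-methylphenyl change leaves compound 3 level with compound 2 in this assay. No measurement available here accounts for this reading.

As far as these compounds go, whether this place accepts groups larger or different in kind from methyl, such as methoxy, an amine or a carboxylic acid, remains open. Also open, from the compounds shown here alone, is whether the same reading would hold with methyl elsewhere on this ring, or with 1-bromonaphthalen-2-yl in place of naphthalen-1-yl as the other aryl group.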